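Pyridin-3-yl for 4-methoxyphenyl in compound 4

The source may hold more compounds than are shown below. What is called first, only, known or untested is meant among the compounds shown, and "the series" means these compounds.

In a functional assay on MCF7 cells (Homo sapiens) for antiproliferative activity, with a stated time of 5 days (a higher number here means a weaker inhibitor, a lower number a stronger inhibitor), compound 1 `CCCCc1ccc2[nH]c(-c3ccc(C(F)(F)F)cc3)c(C=O)c2c1` gives 66 nM, compound 2 `CCCCc1ccc2[nH]c(-c3ccc(OC)cc3)c(/C=N/NC(=O)c3ccc(OC)cc3)c2c1` gives 226 nM and compound 3 `CCCCc1ccc2[nH]c(-c3ccc(C(F)(F)F)cc3)c(/C=N/NC(=O)c3ccc(OC)cc3)c2c1` gives 618 nM. Compound 3 has the highest number of the three and is the weakest inhibitor among them, with compound 2 its nearest neighbour.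

Compound 4 `CCCCc1ccc2[nH]c(-c3ccc(C(F)(F)F)cc3)c(/C=N/NC(=O)c3cccnc3)c2c1` keeps the trifluoromethyl group of compound 3 and changes the other end of the molecule (pyridin-3-yl in place of 4-methoxyphenyl on a carbonyl carbon). In words, pyridin-3-yl stands in place of 4-methoxyphenyl on a carbonyl carbon.

Among the measured compounds shown here, the only measured single change is a 2.7-fold higher number from compound 2 to compound 3 (0.44 log units; beyond the scatter), a modest step beyond the scatter. It comes from trifluoromethyl in place of methoxy on an aromatic carbon, so it lies elsewhere and gives no size for this swap. Compound 1 also carries trifluoromethyl and has a lower number than compound 3, but it lacks this acyl group altogether and is no guide either. For the measured compounds named here, no measured pair tests the group now being changed, so no direction is supported, and the best anchor is compound 3 at 618 nM. No step beyond the scatter is expected, and the estimated step is a 1.1-fold lower number from compound 3 to compound 4 (0.05 log units; within the scatter). For compound 4 the estimated value is 550 nM, with an expected range from 180 nM to 1800 nM.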

Compound 4, half-maximal inhibitory concentration: 260 nM
Beside the measured number, compound 4's estimate is 2.1-fold (0.33 log units) above it, and the stated range covers the measured number.
By their numbers in this assay, from the lowest: compound 1; then compounds 2 and 4 (each within the scatter of the next); then compound 3.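

Working notes: in this assay, the acyl end of the molecule proves responsive, which the earlier compounds could not show because they offered no pair that varied it: pyridin-3-yl in place of 4-methoxyphenyl on a carbonyl carbon gives a 2.4-fold lower number from compound 3 to compound 4 (0.38 log units; beyond the scatter), a modest step towards the stronger inhibitor. Even with pyridin-3-yl in place, the group of 11 heavy atoms on the aromatic carbon still compares unfavourably with the group of 2 heavy atoms it replaces, at a 3.9-fold higher number from compound 1 to compound 4 (0.60 log units; beyond the scatter), so compound 1 retains the lowest number of the series. No measured evidence is available to account for the step from the 4-methoxyphenyl to the pyridin-3-yl group.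

On these data alone, it remains open whether the lower number goes with the ring nitrogen or with the loss of the methoxy group, a question that plain phenyl or pyridin-4-yl on the same carbonyl carbon would address. Also open, as far as these compounds go, is whether the step carries over when methoxy stands in place of trifluoromethyl on the other aromatic ring, and how an amine or a carboxylic acid on the pyridine ring would read here.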